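A Methoxy Group Added to Compound 2

The source may report more compounds than this note shows. Statements on the series, on what has been measured and on what is new or still open speak of the compounds shown alone.

In a functional assay on PC-3 cells (Homo sapiens) for inhibition, read by colorimetric assay and MTT assay, with a stated time of 72 h (a higher number here means a weaker inhibitor, a lower number a stronger inhibitor), compound 1 `Cc1ccc2c(c1)-c1cnc(n1C)OCCCCCCCCO2` gives 36000 nM. Compound 2 `C=CCCCCOc1ccccc1-c1cnc(OCCC=C)n1C` gives 19000 nM, so these two numbers lie within the usual scatter of each other. Compound 3 `C=CCCCCOc1ccc(OC)cc1-c1cnc(OCCC=C)n1C` is compound 2 with methoxy in place of hydrogen on an aromatic carbon. Among the compounds with values here, no measured pair shows what such a change does, so no shift beyond the scatter is expected in this assay. The expected change is a 1.1-fold lower number from compound 2 to compound 3 (0.02 log units; within the scatter), which is a small estimate with no firm direction. For compound 3 the estimated value is 18000 nM, with an expected range of 8000 nM to 40000 nM.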

Compound 3, half-maximal inhibitory concentration: 43000 nM
The estimate for compound 3 lay 2.4-fold (0.38 log units) below the measured number; measured number outside the range, above it.
By their numbers in this assay, from the lowest: compounds 2, 1 and 3 (each within the scatter of the next, the first and the last beyond it).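

Methoxy on this aromatic carbon, para to the (hex-5-en-1-yl)oxy group, gives the first step here that can be read as a single change. In this assay it produces a modest shift (a 2.3-fold higher number from compound 2 to compound 3 (0.35 log units; beyond the scatter)), so this position does respond to a substituent, and here the step goes towards a weaker inhibitor. Nothing available explains the shift.

Going by these compounds, whether fluorine, methyl or an amine on the same carbon would move the number the same way stays open. So does the effect of methoxy on another carbon of this ring.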